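This account rests on a few compounds, and the source may have more. Where it says the series, first, only, none or still open, it means among the compounds named here.

Within the data shown here, compound 2 `CCNC(=O)Nc1ccc(S(=O)(=O)Oc2ccccc2I)cc1` holds the lowest number of the two measured so far in a functional assay on HT-1080 cells (Homo sapiens) for antiproliferative activity, read by sulforhodamine B assay, with a stated time of 48 h (on this read-out higher numbers stand for weaker inhibition and lower numbers for stronger inhibition), where compound 2 gives 140 nM; compound 1 `O=C(CCl)Nc1ccc(S(=O)(=O)Oc2ccccc2I)cc1` gives 600 nM. Among the measured compounds shown here, the only measured step, a 4.3-fold lower number from compound 1 to compound 2 (0.63 log units; beyond the scatter), swaps the whole group on the carbonyl carbon and does not bear closely on the change now made. Compound 3 `CCCNC(=O)Nc1ccc(S(=O)(=O)Oc2ccccc2I)cc1` differs from compound 2 by methyl in place of hydrogen on a saturated chain carbon, two bonds along the chain from an amide-type nitrogen. For the measured compounds named here, with no measured step of this kind, the step in this assay is expected to stay within the scatter, estimated as no change at the digits printed from compound 2 to compound 3 (within the scatter). Compound 3 is therefore expected to give about 140 nM, between 60 nM and 350 nM.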

Compound 3, half-maximal inhibitory concentration: 700 nM
For compound 3 the middle estimate is 5.0-fold (0.70 log units) below the measured one; measured number outside the range, above it.
By their numbers in this assay, from the lowest: compound 2; then compounds 1 and 3 (each within the scatter of the next).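

In this assay, the position proves sensitive to a single added methyl, with ethylamino to propylamino giving a 5.0-fold higher number from compound 2 to compound 3 (0.70 log units; beyond the scatter) on the otherwise unchanged core. That step cancels the advantage ethylamino held over chloromethyl, since the comparison with the earlier compound gives a 1.2-fold higher number from compound 1 to compound 3 (0.07 log units; within the scatter) and the two groups cannot be told apart here. No available evidence explains this sensitivity. Going by these compounds, whether methylamino, butylamino or a longer chain would sit nearer compound 2 or compound 3 stays open, and two chain lengths alone define no trend.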